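The source may report more compounds than this note shows. Statements on the series, on what has been measured and on what is new or still open speak of the compounds shown alone.

Working notes on the series. Compound 1 `N=c1oc2c(O)cccc2cc1C(=O)Nc1ccc(F)cc1` has been measured in an assay on isolated protein for inhibition of Carbonyl reductase [NADPH] 1 (Homo sapiens) (on this read-out lower numbers stand for stronger inhibition and higher numbers for weaker inhibition), and compound 1 gives 440 nM. Compound 2 `N=c1oc2c(O)cccc2cc1C(=O)Nc1ccccc1Cl` differs on the amide-type nitrogen, and in this assay compound 2 gives 34 nM. Among the compounds with values here, the single step measured so far, a 13-fold lower number from compound 1 to compound 2 (1.11 log units; beyond the scatter), is large and well beyond the scatter. Within the data shown here, on the two numbers available compound 2 stands lowest, with compound 1 as its only neighbour.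

Compound 3 `N=c1oc2c(O)cccc2cc1C(=O)Nc1ccccc1C(F)(F)F` has not been measured. It differs from compound 2 by trifluoromethyl in place of chloro on an aromatic carbon. Among the measured compounds shown here, the only measured step that bears on it, a 13-fold lower number from compound 1 to compound 2 (1.11 log units; beyond the scatter), changed the whole substituent pattern of the phenyl at once, so it gives no clean measure of swapping one group for another at the same place. For the measured compounds named here, no measured pair sets chloro against trifluoromethyl. The expectation is therefore a step no larger than the scatter in this assay, with no settled direction, which is written as a 1.2-fold higher number from compound 2 to compound 3 (0.07 log units; within the scatter). In this assay compound 3 is estimated at 40 nM, with an expected range from 12 nM to 130 nM.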

Compound 3, half-maximal inhibitory concentration: 75 nM
For compound 3 the middle estimate is 1.9-fold (0.27 log units) below the measured one; measured number inside the range.
By their numbers in this assay, from the lowest: compound 2; then compound 3; then compound 1.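

In this assay this position now has its first one-place comparison: with trifluoromethyl in place of chloro on an aromatic carbon ortho to a large group, the series shows a 2.2-fold higher number from compound 2 to compound 3 (0.34 log units; beyond the scatter), a modest step. The number therefore depends on which group sits at this place, and of the two groups shown, chloro gives the lower number, although the swap from 1 heavy atom to 4 heavy atoms leaves the hydrogen-bond donor and acceptor counts and the net charge unchanged. No measurement on hand bears on why the number moves with this change.

The compounds shown leave open how a methyl, a methoxy, a nitrile or an amine on the same aromatic carbon would compare with chloro, so two groups are too few to give a trend at this position. Also open, on these data alone, is how much of the earlier gain comes from chloro at this place and how much from the loss of fluoro elsewhere on the phenyl, as that step changed both at once.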